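A few compounds are considered here, and "the series" means these few. Any claim that something is new, unique, unknown or untested is made for them only; others in the source may bear on it.

Compound 3 `Cc1ccc(NC(=S)NC(=O)c2ccc(OCc3ccc(Cl)c(Cl)c3)cc2)cc1-c1nc2ccccc2[nH]1` gives 30700 nM in a functional assay on SW-620 cells (Homo sapiens) for inhibition, read by MTT assay, with a stated time of 48 h (on this read-out lower numbers stand for stronger inhibition and higher numbers for weaker inhibition), the lowest of the two numbers reported there. Compound 2 `Cc1ccc(COc2ccc(C(=O)NC(=S)Nc3ccc(C)c(-c4nc5ccccc5[nH]4)c3)cc2)cc1` gives 60900 nM, and the step of a 2.0-fold lower number from compound 2 to compound 3 (0.30 log units; within the scatter) stays within the scatter, so the two cannot be ranked. Compound 1 `Cc1ccc(NC(=S)NC(=O)c2ccc(OCc3cccc(Cl)c3)cc2)cc1-c1nc2ccccc2[nH]1` reaches only a limit, > 100000 nM. Compound 4 `O=C(NC(=S)Nc1ccc(Cl)c(-c2nc3ccccc3[nH]2)c1)c1ccc(OCc2ccc(Cl)c(Cl)c2)cc1` differs from compound 3 by chloro in place of methyl on an aromatic carbon. Among the compounds with values here, no measured step touches this ring: the steps of an at least 3.2-fold lower number from compound 1 to compound 3 (0.51 log units; beyond the scatter) and an at least 1.6-fold lower number from compound 1 to compound 2 (0.21 log units; that floor lies within the scatter) both change the benzyl group, as does a 2.0-fold lower number from compound 2 to compound 3 (0.30 log units; within the scatter), so they offer no direct guide, and a change no larger than the scatter is expected. The estimate for compound 4 is 25000 nM, from 8000 nM to 80000 nM, an expected step of a 1.2-fold lower number from compound 3 to compound 4 (0.09 log units; within the scatter).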

Compound 4, half-maximal inhibitory concentration: 24900 nM
Compound 4: middle estimate off by 1.0-fold (0.00 log units), on the high side; measured number inside the range.
By their numbers in this assay, from the lowest: compounds 4, 3 and 2 (each within the scatter of the next, the first and the last beyond it). At a limit, above all of these: compound 1.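

Within the data shown here, this is the first measured change at the aromatic carbon ortho to the 1H-benzimidazol-2-yl group: chloro in place of methyl gives a 1.2-fold lower number from compound 3 to compound 4 (0.09 log units; within the scatter) in this assay. With the 3,4-dichlorophenyl group in place, methyl and chloro therefore cannot be told apart at this position. Nothing measured here offers a reason for this result. From the compounds shown here alone, whether an amine or a methoxy group on this carbon would shift the number remains open. So does whether methyl and chloro would also read alike alongside the 3-chlorophenyl or 4-methylphenyl group.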